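The source may report more compounds than this note shows. Statements on the series, on what has been measured and on what is new or still open speak of the compounds shown alone.

Among the measured compounds shown here, compound 1 `C#CCSc1cnc2ccccc2c1[Se]CC#CCCl` is one of two compounds measured so far. In a functional assay on P388 cells (Mus musculus) for antiproliferative activity, with a stated time of 72 h (on this read-out higher numbers stand for weaker inhibition and lower numbers for stronger inhibition), compound 1 gives 0.8 ug/mL, which is the lowest of the two numbers recorded. For the measured compounds named here, the only other measured compound, compound 2 `O=C(/C=C/c1ccccc1)OCC#CCSc1cnc2ccccc2c1Cl`, gives 32.8 ug/mL in this assay; its number is higher than that of compound 1 by a margin well beyond the usual scatter, so compound 1 is the stronger inhibitor of the pair. Going by the values given here, compound 2 differs from compound 1 in several places at once, so no single structural step connects them, and their two numbers show only that the pair lies far apart.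

Compound 3 `CSc1cnc2ccccc2c1[Se]CC#CCCl` has not been measured yet. It differs from compound 1 in one place: hydrogen in place of ethynyl on a saturated chain carbon bound to a sulfur. Put another way, the propargyl group becomes a methyl group, so propargylsulfanyl becomes methylsulfanyl. Among the compounds with values here, no measured pair shows what this kind of change does here. The step expected in this assay is a small one toward a higher number, a 1.9-fold higher number from compound 1 to compound 3 (0.27 log units; within the scatter), close to the scatter. Compound 3 is therefore expected to give about 1.5 ug/mL, within a range from 0.5 ug/mL to 5 ug/mL.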

Compound 3, concentration for 50% inhibition: 0.4 ug/mL
Compound 3: the middle estimate sits 3.8-fold (0.57 log units) above what was measured, and the stated range ends above it.
By their numbers in this assay, from the lowest: compounds 3 and 1 (each within the scatter of the next); then compound 2.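

In this assay, among the compounds shown here, the swap of propargylsulfanyl for methylsulfanyl gives the first single change that can be read, with a 2.0-fold lower number from compound 1 to compound 3 (0.30 log units; within the scatter) lying within the usual scatter of repeated measurements. Compound 1 and compound 3 therefore cannot be told apart in this assay, which shows that, in this pair, the ethynyl group on a saturated chain carbon bound to a sulfur can give way to hydrogen, with its triple bond and two carbon atoms gone, and the number stays in the same range. Nothing measured here offers a reason why the two numbers agree.

Going by these compounds, this single pair compares only ethynyl and hydrogen at this place, so it remains open whether a longer chain such as propyl, an amine or a carboxylic acid on the same carbon would also stay in that range. On these data alone, it is also open whether the same step would read alike on a different core or in a different assay.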